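Dimethylphenyl isomers on the sulfonamide nitrogen

The source may report more compounds than this note shows. Statements on the series, on what has been measured and on what is new or still open speak of the compounds shown alone.

Measured in a functional assay (CEM-VLB cells, Homo sapiens) for antiproliferative activity, read by sulforhodamine B assay, with a stated time of 48 h; a lower number here means a stronger inhibitor, a higher number a weaker inhibitor:
- compound 1 `Cc1cccc(NS(=O)(=O)c2ccc(N3CCNC3=O)cc2)c1`: 370 nM
- compound 2 `O=C1NCCN1c1ccc(S(=O)(=O)Nc2cccc(Br)c2)cc1`: 250 nM
- compound 3 `Cc1cc(C)cc(NS(=O)(=O)c2ccc(N3CCNC3=O)cc2)c1`: 400 nM

Compound 3 at 400 nM lies within the scatter of both other compounds, so the three values are not separated. The next compound to be measured is compound 4 `Cc1ccc(C)c(NS(=O)(=O)c2ccc(N3CCNC3=O)cc2)c1`, which has 2,5-dimethylphenyl in place of 3,5-dimethylphenyl on a sulfonamide nitrogen. For the measured compounds named here, three measured steps bear on this change. They are a 1.1-fold higher number from compound 1 to compound 3 (0.03 log units; within the scatter), a 1.5-fold lower number from compound 1 to compound 2 (0.17 log units; within the scatter) and a 1.6-fold higher number from compound 2 to compound 3 (0.20 log units; within the scatter), and all three stay within the scatter. Going by the values given here, none of the measured compounds carries the 2,5-dimethylphenyl group, so this change has no direct precedent. No step beyond the scatter is therefore expected in this assay, though the range is kept wide to allow for that gap. The expected size is no change at the digits printed from compound 3 to compound 4 (within the scatter). The estimate for compound 4 is 400 nM, with an expected range from 170 nM to 950 nM.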

Compound 4, half-maximal inhibitory concentration: 120 nM
The estimate for compound 4 lay 3.3-fold (0.52 log units) above the measured number, outside the stated range (below it).
By their numbers in this assay, from the lowest: compound 4; then compounds 2, 1 and 3 (each within the scatter of the next).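

In this assay the 2,5-dimethylphenyl group in place of 3,5-dimethylphenyl on the sulfonamide nitrogen gives the first separation in the series: a 3.3-fold lower number from compound 3 to compound 4 (0.52 log units; beyond the scatter), although both groups have the same atoms and the same counts, so the arrangement of the two methyl groups matters here and not only their presence. Compound 4 also stands clear of the other two, with a 2.1-fold lower number from compound 2 to compound 4 (0.32 log units; beyond the scatter) and a 3.1-fold lower number from compound 1 to compound 4 (0.49 log units; beyond the scatter), which makes it the strongest of the four in this assay. No measurement shown gives a reason for this difference.

Still open, going by these compounds, is whether both methyl groups of the 2,5-dimethylphenyl group are needed, or whether one alone would do. Also open, on these data alone, is whether a methoxy group, an amine or a carboxylic acid on this ring would keep the level of compound 4.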